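This account rests on a few compounds, and the source may have more. Where it says the series, first, only, none or still open, it means among the compounds named here.

Values in an ADME assay on a cell-free system (plasma, Homo sapiens) for metabolic stability, read by LC-MS (a higher number here means that the compound lasts longer, a lower number that the compound disappears faster), measured so far:
- compound 1 `CCCOC(=O)c1ccc(NC(=O)c2cccc(-c3cc(C(=O)Nc4ccncc4F)ccc3CN)c2)cc1` gives > 2 h as a limit
- compound 2 `NCc1ccc(C(=O)Nc2ccncc2F)cc1-c1cccc(C(=O)Nc2ccc(CC(=O)O)cc2)c1` gives > 2 h as a limit
- compound 3 `COC(=O)c1cccc(NC(=O)c2cccc(-c3cc(C(=O)Nc4ccncc4F)ccc3CN)c2)c1F` gives < 0.0834 h as a limit

Compound 3 holds < 0.0834 h as a limit and has no exact number. Compound 4 (`CC(C)OC(=O)c1cccc(NC(=O)c2cccc(-c3cc(C(=O)Nc4ccncc4F)ccc3CN)c2)c1`) takes 3-(isopropoxycarbonyl)phenyl in place of 2-fluoro-3-(methoxycarbonyl)phenyl on an amide-type nitrogen. Going by the values given here, two measured steps bear on this. Both an at least 23-fold lower number from compound 1 to compound 3 (1.37 log units; beyond the scatter) and an at least 23-fold lower number from compound 2 to compound 3 (1.37 log units; beyond the scatter) are large and bring in the group that compound 4 gives up, while a step that the two limits leave unreadable from compound 1 to compound 2 cannot be read. Compound 4 drops that group, so a large rise in this assay is expected, though its ester differs from that of compound 1. The expected change is an at least 7.1-fold higher number from compound 3 to compound 4 (0.85 log units; beyond the scatter) overall. For compound 4 the estimate is 0.6 h with a range from 0.1 h to 2.5 h as expected bounds.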

Compound 4, half-life: 0.567 h
Compound 4: middle estimate off by 1.1-fold (0.02 log units), on the high side; the measured number falls inside the stated range.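

In this assay, three esters on this amide-type nitrogen now give three different outcomes, so carrying an ester does not by itself set the half-life, as an at least 6.7-fold higher number from compound 3 to compound 4 (0.83 log units; beyond the scatter), an at least 3.5-fold lower number from compound 1 to compound 4 (0.54 log units; beyond the scatter) and an at least 3.5-fold lower number from compound 2 to compound 4 (0.54 log units; beyond the scatter) show. These steps are bounds and not sizes, and compound 3 stands at a limit: the limit of < 0.0834 h in this assay, at which 1 of the 4 values shown sits. Compounds 1 and 2 also stand at a limit: the limit of > 2 h in this assay, at which 2 of the 4 values shown sit.

The change from compound 3 to compound 4 swaps the fluorine and the ester chain together, so the compounds shown leave open which of the two carries the rise. Going by these compounds, how a 3-(methoxycarbonyl)phenyl group without the fluorine would stand also remains open.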